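This account rests on a few compounds, and the source may have more. Where it says the series, first, only, none or still open, it means among the compounds named here.

Measured compounds:
compound 1 `O=S(=O)(Nc1cc(-c2cnc3[nH]ncc3c2)cnc1Cl)c1ccccc1`: 7610 nM
compound 2 `O=S(=O)(Nc1cc(-c2cnc3[nH]cc(-c4ccncc4)c3c2)cnc1Cl)c1ccc(F)cc1`: 6190 nM

Both were tested in a functional assay on NCI-H460 cells (Homo sapiens) for inhibition, read by sulforhodamine B assay, with a stated time of 72 h; a lower number here means a stronger inhibitor of growth, a higher number a weaker inhibitor of growth. Compound 1 gives 7610 nM. Compound 2 gives 6190 nM. The two numbers lie within the usual scatter of each other, so compound 1 cannot be set apart from compound 2 on growth inhibition. Going by the values given here, compound 2 also carries a pyridin-4-yl group and a fluorine, but no single-change pair connects it to compound 1.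

Compound 3 `O=S(=O)(Nc1cc(-c2cnc3[nH]nc(-c4ccncc4)c3c2)cnc1Cl)c1ccccc1` is not yet measured. It differs from compound 1 by one change: pyridin-4-yl in place of hydrogen on an aromatic carbon of the shared core. Among the compounds with values here, no measured pair isolates this change. Compound 2, which also bears a pyridin-4-yl on its core, gives 6190 nM, close to compound 1, so only a small shift is expected. The expected step in this assay is a 1.4-fold lower number from compound 1 to compound 3 (0.14 log units; within the scatter), possibly within the scatter. Compound 3 is expected to give about 5500 nM in this assay, within 1500 nM to 20000 nM.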

Compound 3, concentration for 50% growth inhibition: 2500 nM
For compound 3 the middle estimate is 2.2-fold (0.34 log units) above the measured one; measured number inside the range.
By their numbers in this assay, from the lowest: compound 3; then compounds 2 and 1 (each within the scatter of the next).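

Placing pyridin-4-yl in place of hydrogen on an aromatic carbon of the five-membered aromatic ring gives a 3.0-fold lower number from compound 1 to compound 3 (0.48 log units; beyond the scatter) in this assay. Going by these compounds alone, this is the first single-change pair in the set, and it shows that this carbon can carry a six-membered aromatic ring without any loss of growth inhibition, with a modest gain instead. Nothing measured here explains the gain.

The compounds shown leave open whether a plain phenyl ring, which has no ring nitrogen, or a methyl group or an amine on the same carbon would give a similar number. Within the data shown here, with only this one pair, they also leave open whether the same step would appear on other compounds.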